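Furanoyl to tosyl on the amine nitrogen of a dodecyl amide

This account rests on a few compounds, and the source may have more. Where it says the series, first, only, none or still open, it means among the compounds named here.

Compound 1 `CCCCCCCCNC(=O)[C@@H](NC(=O)c1ccco1)[C@@H](C)O` and compound 2 `CCCCCCCCCCCCNC(=O)[C@@H](NC(=O)c1ccco1)[C@@H](C)O` were tested in a functional assay on HepG2 cells (Homo sapiens) for cytotoxicity, read by MTT assay, with a stated time of 48 h (a higher number here means a weaker inhibitor, a lower number a stronger inhibitor), where compound 1 gives 192000 nM and compound 2 gives 147000 nM; the step of a 1.3-fold lower number from compound 1 to compound 2 (0.12 log units; within the scatter) is the only measured one. Compound 2 stands lowest of the two numbers, but within the scatter of compound 1. Compound 3 `CCCCCCCCCCCCNC(=O)[C@@H](NS(=O)(=O)c1ccc(C)cc1)[C@@H](C)O` carries the change ((4-methylphenyl)sulfonyl in place of (furan-2-yl)carbonyl on an amine nitrogen). Among the compounds with values here, no measured step touches the amine nitrogen, so nothing here speaks to its size or direction. Compound 3 is therefore expected to sit near compound 2, with a step of a 1.1-fold lower number from compound 2 to compound 3 (0.05 log units; within the scatter). Compound 3 is estimated at 130000 nM, between 40000 nM and 400000 nM.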

Compound 3, half-maximal inhibitory concentration: 25800 nM
Compound 3: middle estimate off by 5.0-fold (0.70 log units), on the high side; measured number outside the range, below it.
By their numbers in this assay, from the lowest: compound 3; then compounds 2 and 1 (each within the scatter of the next).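

In this assay, the amine nitrogen turns out to be a position that responds: (4-methylphenyl)sulfonyl in place of (furan-2-yl)carbonyl gives a 5.7-fold lower number from compound 2 to compound 3 (0.76 log units; beyond the scatter). Within the data shown here, the only earlier step, on the saturated chain, stayed within the scatter, so this is the first change to move the number clearly. No available evidence explains this step.

On these data alone, it remains open whether the sulfonyl or the methylphenyl ring carries the effect, which a benzoyl or a methanesulfonyl group on the same nitrogen could separate. As far as these compounds go, how an octyl chain would read alongside the (4-methylphenyl)sulfonyl group also remains open.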